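Replacing one fluoro on compound 3

The compounds below may be only part of what the source reports. "The series", "measured", "known", "first", "only" and "open" are said of these compounds alone.

Measured in a functional assay on MCF7 cells (Homo sapiens) for cytotoxicity; on this read-out lower numbers stand for stronger inhibition of growth and higher numbers for weaker inhibition of growth:
- compound 1 `COc1ccc(NS(=O)(=O)c2cc(F)c(F)c(F)c2F)cc1`: 120 nM
- compound 2 `COc1ccc(NS(=O)(=O)c2c(F)c(F)c(F)c(Br)c2F)cc1`: 270 nM
- compound 3 `COc1ccc(NS(=O)(=O)c2c(F)cc(F)c(F)c2F)cc1`: 4500 nM

Compound 3 has the highest number of the three, at 4500 nM. Compound 4 `COc1ccc(NS(=O)(=O)c2ccc(F)c(F)c2F)cc1` differs from it by one change: hydrogen in place of fluoro on an aromatic carbon. This is hydrogen in place of fluoro on an aromatic carbon, ortho to a large group.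

Within the data shown here, the only measured step, a 17-fold higher number from compound 2 to compound 3 (1.22 log units; beyond the scatter), is large and also brings in hydrogen on an aromatic carbon. However, bromo leaves there, not fluoro, so it is a weak guide and its direction is not carried over. Compound 1 also has hydrogen ortho to a large group and gives 120 nM, well under the number of compound 3. Among the measured compounds shown here, its fluoro pattern still differs from that of compound 4, and no measured pair isolates this change. A moderate move to a lower number is therefore expected, with wide uncertainty, as a 4.5-fold lower number from compound 3 to compound 4 (0.65 log units; beyond the scatter). For compound 4 the estimated value is 1000 nM, with an expected range of 200 nM to 5000 nM.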

Compound 4, concentration for 50% growth inhibition: > 50000 nM
Compound 4: a limit, no number; the forecaster's own chance of this, stated with the estimate: 3%; middle value at least 50-fold (1.69 log units) from the limit.
By their numbers in this assay, from the lowest: compound 1; then compound 2; then compound 3. At a limit, above all of these: compound 4.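

Compound 4 gives a limit and not a number: the limit of > 50000 nM in this assay, at which 1 of the 4 values shown sits.

In this assay, hydrogen in place of this fluoro, on the aromatic carbon ortho to a large group, gives an at least 11-fold higher number from compound 3 to compound 4 (1.04 log units; beyond the scatter), so compound 3 does not tolerate losing it. Hydrogen in place of fluoro on a different aromatic carbon gives an at least 410-fold higher number from compound 1 to compound 4 (2.61 log units; beyond the scatter), and compound 1, which has hydrogen ortho to a large group, shows that such a hydrogen does not alone bring compound 4 to its limit; the outcome depends on the whole fluoro pattern.

Going by these compounds, the true size of both steps stays open, as each ends at a limit. Also open is how a chloro, a methyl or an amine would behave on this aromatic carbon, since only fluoro and hydrogen are shown there.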